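Indolyl amine swap on the difluorophenyl sulfone series

The source may report more compounds than this note shows. Statements on the series, on what has been measured and on what is new or still open speak of the compounds shown alone.

Measured in a functional assay on DU-145 cells (Homo sapiens) for inhibition, read by trypan blue exclusion, with a stated time of 72 h; a higher number here means a weaker inhibitor, a lower number a stronger inhibitor:
- compound 1 `Cn1c(=O)c(S(=O)(=O)c2ccc(F)cc2)cc2cnc(Nc3ccc4cc[nH]c4c3)nc21`: 10000 nM
- compound 2 `Cn1c(=O)c(S(=O)(=O)c2ccc(F)cc2F)cc2cnc(Nc3ccncn3)nc21`: 50000 nM
- compound 3 `Cn1ccc2cc(Nc3ncc4cc(S(=O)(=O)c5ccc(F)cc5F)c(=O)n(C)c4n3)ccc21`: 750 nM

Compound 3, at 750 nM, has the lowest number of the three. Compound 1 comes nearest at 10000 nM, and compound 2 lies furthest at 50000 nM.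

Next in this assay is compound 4 `Cn1c(=O)c(S(=O)(=O)c2ccc(F)cc2F)cc2cnc(Nc3ccc4cc[nH]c4c3)nc21`, which differs from compound 3 as follows: 1H-indol-6-yl in place of 1-methyl-1H-indol-5-yl on a nitrogen on an aromatic ring. Going by the values given here, only one measured step changes the same place, a 67-fold lower number from compound 2 to compound 3 (1.82 log units; beyond the scatter), with 1-methyl-1H-indol-5-yl in place of pyrimidin-4-yl. It shows that this place can move the number substantially, but it does not compare two indolyl groups. The closest evidence is compound 1, which also carries 1H-indol-6-yl and gives 10000 nM, although it differs from compound 4 elsewhere. A moderate move to a higher number is therefore expected, beyond the scatter but with little certainty. The expected change is a 4.0-fold higher number from compound 3 to compound 4 (0.60 log units; beyond the scatter). For compound 4 the estimated value is 3000 nM, with an expected range of 800 nM to 11000 nM.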

Compound 4, half-maximal inhibitory concentration: 5000 nM
For compound 4 the middle estimate is 1.7-fold (0.22 log units) below the measured one; measured number inside the range.
By their numbers in this assay, from the lowest: compound 3; then compounds 4 and 1 (each within the scatter of the next); then compound 2.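

In this assay the two indolyl groups are not interchangeable at this place: 1H-indol-6-yl in place of 1-methyl-1H-indol-5-yl gives a 6.7-fold higher number from compound 3 to compound 4 (0.82 log units; beyond the scatter) and so this position distinguishes even between closely related indolyl groups. The advantage over pyrimidin-4-yl is not confined to the methylated group, since 1H-indol-6-yl also gives a 10-fold lower number from compound 2 to compound 4 (1.00 log units; beyond the scatter) in the same series. With 1H-indol-6-yl held constant, fluoro in place of hydrogen on an aromatic carbon gives a 2.0-fold lower number from compound 1 to compound 4 (0.30 log units; within the scatter) and no effect of that fluoro can be read from this pair.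

Nothing available explains any of these steps.
The step from compound 3 to compound 4 combines the loss of the methyl with a change of indole attachment, and 1H-indol-5-yl on the same nitrogen would separate the two.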